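The compounds below may be only part of what the source reports. "The series", "measured", "known", "first", "only" and "open" are said of these compounds alone.

Compound 1 `CN(Cc1ccccc1)S(=O)(=O)c1ccc(NC(=O)NCc2ccncc2)cc1`: 23 nM
Compound 2 `CCOC(=O)c1ccc(NC(=O)NCc2c[nH]nn2)cc1`: 7750 nM
Compound 3 `CCOC(=O)c1ccc(NC(=O)NCc2cn[nH]c2)cc1`: 1850 nM

In an assay on isolated protein for activation of Nicotinamide phosphoribosyltransferase (Homo sapiens) (a lower number here means that less compound is needed, a higher number that more compound is needed for the effect), compound 1 stands lowest of the three, with compound 3 nearest and compound 2 furthest. Compound 4 `CCN(CC)S(=O)(=O)c1ccc(NC(=O)NCc2ccncc2)cc1` differs from compound 1 in one place: diethylamino in place of benzyl(methyl)amino on a sulfonyl sulfur. No measured step covers a change on the sulfonyl sulfur; the only step shown, a 4.2-fold lower number from compound 2 to compound 3 (0.62 log units; beyond the scatter), concerns the other end of the shared core and says nothing about this position. Among the measured compounds shown here, compounds 2 and 3 carry an ester where compound 1 carries the sulfonyl group, and their values lie far higher, but each differs from compound 1 in two places, so they yield no step. Without a guide, only a small rise, a 2.2-fold higher number from compound 1 to compound 4 (0.34 log units; beyond the scatter), is expected. Compound 4 is estimated at 50 nM in this assay, within 15 nM to 200 nM.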

Compound 4, half-maximal effective concentration: 384 nM
For compound 4 the middle estimate is 7.7-fold (0.89 log units) below the measured one; measured number above the stated range.
By their numbers in this assay, from the lowest: compound 1; then compound 4; then compound 3; then compound 2.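

On the sulfonyl sulfur, the core of compound 1 does not tolerate every amine equally in this assay, with diethylamino in place of benzyl(methyl)amino giving a 17-fold higher number from compound 1 to compound 4 (1.22 log units; beyond the scatter), a large step. Between the two groups, the six-membered aromatic ring of carbon only is lost and the heavy atoms fall from 9 to 5, while hydrogen-bond donors, hydrogen-bond acceptors and net charge stay unchanged. No measurement shown explains this step. As far as these compounds go, it remains open whether the step follows the ring or the heavy-atom count. Piperidin-1-yl or dibenzylamino on the sulfonyl sulfur would help separate the two.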